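Replacing a Chloroamide With an Ester: Expected Cytotoxicity

The compounds below may be only part of what the source reports. "The series", "measured", "known", "first", "only" and "open" are said of these compounds alone.

Compound 1, `COc1ccc(C(=O)Nc2ccccc2)cc1NC(=O)C(C)Cl`, gives 200 uM in an ADME assay on MDCK cells (Canis lupus familiaris) for cytotoxicity, read by cytopathic effect, with a stated time of 48 h; on this read-out lower numbers stand for higher toxicity in this test and higher numbers for lower toxicity in this test.
Compound 2, `CCC(=O)Nc1cc(C(=O)Nc2ccccn2)ccc1OC`, gives > 668 uM in this assay, which is a limit of the assay rather than a number (the limit of > 668 uM in this assay, at which 1 of the 2 values shown sits).

Within the data shown here, compound 1 therefore holds the only measured number here, with the other value being a limit. Compound 3, `CCC(=O)Oc1cc(C(=O)Nc2ccccc2)ccc1OC`, differs from compound 1 by propanoyloxy in place of ((1-chloroethyl)carbonyl)amino on an aromatic carbon. Among the measured compounds shown here, no measured pair shows this change, so its effect in this assay cannot be read from the data. Still, a step toward lower toxicity, larger than the usual scatter, is expected. The step this expectation implies is a 2.0-fold higher number from compound 1 to compound 3 (0.30 log units; within the scatter). Compound 3 is estimated to give 400 uM, within 150 uM to 1000 uM.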

Compound 3, half-maximal toxic concentration: 519 uM
Estimate against measurement, compound 3: 1.3-fold (0.11 log units) below, within the range that was stated.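

In this assay, putting propanoyloxy in place of ((1-chloroethyl)carbonyl)amino on this aromatic carbon, ortho to a methoxy group, gives a 2.6-fold higher number from compound 1 to compound 3 (0.41 log units; beyond the scatter). This shows that the change moves the read-out toward lower toxicity in this test by more than the usual scatter. Compound 2 remains a limit of the assay rather than a number: the limit of > 668 uM in this assay, at which 1 of the 3 values shown sits.

The change removes the chlorine and alters the link to the ring together, so the compounds shown cannot separate these two parts. Going by these compounds, how an amine or a longer ester chain would read at this position also stays open.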